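Adding trifluoromethyl to the longer-lasting compound

The compounds below may be only part of what the source reports. "The series", "measured", "known", "first", "only" and "open" are said of these compounds alone.

For the measured compounds named here, compound 1 `O=C(Sc1cccnc1C(=O)O)c1ccccc1` stands highest of the two compounds measured so far in a physicochemical assay for pharmacokinetics, at pH 8; a higher number here means that the compound lasts longer, a lower number that the compound disappears faster: compound 1 gives 60.1 h, whereas compound 2 `O=C(Sc1cccnc1C(=O)O)c1ccc(Cl)cc1` gives 26.6 h. Compound 3 `O=C(Sc1cccnc1C(=O)O)c1cccc(C(F)(F)F)c1` has not yet been measured. It keeps the core of compound 1 but carries trifluoromethyl in place of hydrogen on an aromatic carbon, meta to a large group: trifluoromethyl in place of hydrogen on an aromatic carbon.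

Going by the values given here, only one measured step bears on this change: a 2.3-fold lower number from compound 1 to compound 2 (0.35 log units; beyond the scatter), where chloro took the place of hydrogen on an aromatic carbon. That step was modest but beyond the scatter. It is thin evidence, since trifluoromethyl is a different group, yet it points to a modest fall in this assay. The expected change is a 3.0-fold lower number from compound 1 to compound 3 (0.48 log units; beyond the scatter). Compound 3 is estimated at 20 h, with an expected range of 10 h to 38 h.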

Compound 3, half-life: 10 h
The estimate for compound 3 lay 2.0-fold (0.30 log units) above the measured number; the range from low to high includes it.
By their numbers in this assay, from the lowest: compound 3; then compound 2; then compound 1.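

In this assay, for the compounds shown here, trifluoromethyl in place of hydrogen on an aromatic carbon, meta to a large group, brings a 6.0-fold lower number from compound 1 to compound 3 (0.78 log units; beyond the scatter), so chloro is not the only group that lowers the number relative to compound 1. Compound 1 now stands highest of the three, with both substituted compounds lasting for a shorter time than this compound with hydrogen on the ring. No measurement shown here accounts for the fall.

The compounds shown leave open whether trifluoromethyl would lower the number to the same extent at another place on the ring. They also leave open how a group without a halogen, such as an amine or a methoxy group, would behave at this position.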